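Adding an amino group to compound 2

The source may hold more compounds than are shown below. What is called first, only, known or untested is meant among the compounds shown, and "the series" means these compounds.

Values in an ADME assay on BJ cells (Homo sapiens), read by MTT assay, with a stated time of 72 h; a higher number here means a weaker inhibitor, a lower number a stronger inhibitor:
- Compound 1 `Cc1ncnc2c1c(-c1ccsc1)cn2[C@@H]1O[C@H](CO)[C@@H](O)[C@H]1O`: 96900 nM
- Compound 2 `O=c1[nH]cnc2c1c(-c1ccccc1)cn2[C@@H]1O[C@H](CO)[C@@H](O)[C@H]1O`: > 100000 nM (a limit, not a number)
- Compound 3 `O=c1[nH]cnc2c1c(-c1cc3ccccc3o1)cn2[C@@H]1O[C@H](CO)[C@@H](O)[C@H]1O`: 62700 nM

Compound 2 gives only a limit in this assay, so it has no exact place on this scale. It stands at the limit of > 100000 nM in this assay, at which 1 of the 3 values shown sits.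

Compound 4 `Nc1nc2c(c(-c3ccccc3)cn2[C@@H]2O[C@H](CO)[C@@H](O)[C@H]2O)c(=O)[nH]1` has not been measured yet. It differs from compound 2 by one change: amino in place of hydrogen on an aromatic carbon. The new amino group sits between two ring nitrogen atoms.

Among the compounds with values here, only one measured step starts from compound 2, and that is an at least 1.5-fold lower number from compound 2 to compound 3 (0.20 log units; that floor lies within the scatter). It replaces phenyl with 1-benzofuran-2-yl, which is a different change at a different place, so it gives no direct size for adding an amino group. Within the data shown here, with no measured step at this place, no step beyond the scatter is expected in this assay, in either direction.

The estimated step is a number no higher from compound 2 to compound 4 (the limit leaves the size open), and this is an expectation only. For compound 4 the expected value is 100000 nM, with an estimated range from 45000 nM to 220000 nM. Compound 4 may well return only a limit too, as is expected more often than not.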

Compound 4, half-maximal inhibitory concentration: > 100000 nM
Compound 4: only a limit was reported; the forecaster's own chance of this, stated with the estimate: 65%; the middle value lies on the limit itself.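

In this assay compound 4 gives > 100000 nM, a limit and not a number. Compound 2 gives > 100000 nM, also a limit, so no step can be read between compound 2 and compound 4: the limit of > 100000 nM in this assay, at which 2 of the 4 values shown sit.

The compounds shown leave open whether amino in place of hydrogen changes the value at all, and in which direction.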